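A Pyridine Ring Replaces 4-Ethylphenyl on Sulfur

A few compounds are considered here, and "the series" means these few. Any claim that something is new, unique, unknown or untested is made for them only; others in the source may bear on it.

In a functional assay on HCT-116 cells (Homo sapiens) for inhibition, read by CCK-8 assay, with a stated time of 72 h, tested at 2 uM (a lower number here means less inhibition of growth, a higher number more inhibition of growth at the concentration tested), compound 3 (`CCc1ccc(SCc2ccc(/C=C/C(=O)Nc3ccccc3N)cc2)cc1`) gives 3.29% and stands within the scatter of the two other measured compounds. Compound 1 (`COc1ccc(SCc2ccc(/C=C/C(=O)Nc3ccccc3N)cc2)cc1OC`) gives 12.9% and compound 2 (`Nc1ccccc1NC(=O)/C=C/c1ccc(CSc2ccc(Cl)cc2)cc1`) gives 5.62% in the same test. Compound 4 (`Nc1ccccc1NC(=O)/C=C/c1ccc(CSc2ccc(C(F)(F)F)cn2)cc1`) differs from compound 3 on a sulfur, where 5-(trifluoromethyl)pyridin-2-yl stands in place of 4-ethylphenyl (5-(trifluoromethyl)pyridin-2-yl in place of 4-ethylphenyl on a sulfur). For the measured compounds named here, three measured steps bear on this, each a change of the group on that sulfur: a number 7.3 percentage points lower from compound 1 to compound 2 (within the scatter) and a number 9.6 percentage points lower from compound 1 to compound 3 (within the scatter) and also a number 2.3 percentage points lower from compound 2 to compound 3 (within the scatter) in the swap of chloro for ethyl. None of them brings in a ring with a hetero atom, so they speak to the new ring only indirectly. With these three steps as the guide, no step beyond the scatter is expected in this assay for this swap. The expected size is a number 3.7 percentage points higher from compound 3 to compound 4 (within the scatter) at most a small move. Compound 4 is expected at 7% with an estimated range from 0% to 18% at the tested concentration.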

Compound 4, percent growth inhibition at one concentration: 4.42%
For compound 4 the middle estimate is 2.6 percentage points above the measured one; the range from low to high includes it.
By their numbers in this assay, from the lowest: compounds 3, 4, 2 and 1 (each within the scatter of the next).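

In this assay the 5-(trifluoromethyl)pyridin-2-yl group brings the first ring with a hetero atom onto the sulfur, and the steps to it all stay within the scatter: a number 1.1 percentage points higher from compound 3 to compound 4 (within the scatter) and a number 1.2 percentage points lower from compound 2 to compound 4 (within the scatter) and also a number 8.5 percentage points lower from compound 1 to compound 4 (within the scatter) at the tested concentration. All four compounds now lie within the scatter of one another, so this position has shown no measurable difference among these groups, whether the ring carries carbon only or a hetero atom. Nothing at hand gives a reason for this result.

The ring nitrogen and the trifluoromethyl group enter together in compound 4, so the compounds shown do not separate the two. From the compounds shown here alone, whether an amine or a carboxylic acid on that ring, or a longer chain on the sulfur in its place, would give a step beyond the scatter remains open.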